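The source may report more compounds than this note shows. Statements on the series, on what has been measured and on what is new or still open speak of the compounds shown alone.

Working notes on a shared core varied only in the group on the pendant benzene. Compound 1 `COc1ccc(-c2cc(-c3ccc(S(=O)(=O)N(C)C)cc3)cnc2N)cn1` carries dimethylsulfamoyl there, and in an in vitro ADME assay on microsomes from liver (Homo sapiens) for metabolic stability (on this read-out higher numbers stand for a longer-lived compound and lower numbers for a shorter-lived compound), compound 1 gives 0.292 h. Compound 2 `COc1ccc(-c2cc(-c3ccc(NS(C)(=O)=O)cc3)cnc2N)cn1` carries methanesulfonamido in that position. In this assay compound 2 reaches > 4.16 h, which is a limit of the assay rather than a number; this is the limit of > 4.16 h in this assay, at which 1 of the 2 values shown sits. The measured step of an at least 14-fold higher number from compound 1 to compound 2 (1.15 log units; beyond the scatter) is accordingly itself only a lower bound. Compound 3 `COc1ccc(-c2cc(-c3ccc(C(F)(F)F)cc3)cnc2N)cn1` is not yet measured; it differs from compound 2 by trifluoromethyl in place of methanesulfonamido on an aromatic carbon. Among the measured compounds shown here, no measured step involves a trifluoromethyl, and the single known step concerns a different exchange, so it gives no direct guide to the size or direction of the change in this assay between compound 2 and compound 3. Compound 3 is therefore estimated at 2.5 h, within 0.6 h to 8 h, corresponding to an expected step of an at least 1.6-fold lower number from compound 2 to compound 3 (0.22 log units; that floor lies within the scatter).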

Compound 3, half-life: 4.75 h
Beside the measured number, compound 3's estimate is 1.9-fold (0.28 log units) below it; the measured number falls inside the stated range.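

In this assay, trifluoromethyl in place of dimethylsulfamoyl gives a 16-fold higher number from compound 1 to compound 3 (1.21 log units; beyond the scatter). The large gain at this position is therefore not tied to methanesulfonamido: a second group, containing no sulfur and no nitrogen, also lies far from compound 1, which is the shortest-lived of the three on steps beyond the scatter. The step between compound 2 and compound 3 cannot be read, because compound 2 stands at a limit of the assay: the limit of > 4.16 h in this assay, at which 1 of the 3 values shown sits.

Among the compounds shown here, how compound 2 and compound 3 rank against each other remains open, so the shared result is only that both exceed compound 1. Also open, from the compounds shown here alone, is whether the short life of compound 1 belongs to dimethylsulfamoyl specifically or extends to related groups, such as an unsubstituted sulfamoyl, a methylsulfamoyl or a simple amine on the pendant benzene.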